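A few compounds are considered here, and "the series" means these few. Any claim that something is new, unique, unknown or untested is made for them only; others in the source may bear on it.

Three compounds share one core and differ only in the group on the ring attached through the sulfonyl. Compound 1 `COc1cc(Nc2nc3ccccc3nc2S(=O)(=O)c2ccc(C)cc2)cc(OC)c1` carries a methyl there, compound 2 `COc1ccc(S(=O)(=O)c2nc3ccccc3nc2Nc2cc(OC)cc(OC)c2)cc1` a methoxy, and compound 3 `COc1cc(Nc2nc3ccccc3nc2S(=O)(=O)c2ccc(Br)cc2)cc(OC)c1` a bromo. In a functional assay on HL-60 cells (Homo sapiens) for cytotoxicity, read by MTT assay, with a stated time of 72 h (a higher number here means a weaker inhibitor, a lower number a stronger inhibitor), compound 1 gives 20 nM, compound 2 gives 1710 nM, and compound 3 gives 2540 nM. Compound 3 thus has the highest number of the three, though a 1.5-fold higher number from compound 2 to compound 3 (0.17 log units; within the scatter) stays within the scatter, while a 130-fold higher number from compound 1 to compound 3 (2.10 log units; beyond the scatter).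

Compound 4 `COc1cc(Nc2nc3ccccc3nc2S(=O)(=O)c2ccc(F)cc2)cc(OC)c1` is the next member; its change from compound 3 is fluoro in place of bromo on an aromatic carbon. Going by the values given here, three measured steps bear on this. Both an 86-fold higher number from compound 1 to compound 2 (1.93 log units; beyond the scatter) and a 130-fold higher number from compound 1 to compound 3 (2.10 log units; beyond the scatter) were large, but both involved losing the methyl. Among the compounds with values here, the only swap between two groups other than methyl, a 1.5-fold higher number from compound 2 to compound 3 (0.17 log units; within the scatter), produced nothing beyond the scatter. A halogen-for-halogen swap resembles that second kind of step, so no change beyond the scatter is expected, with a wide range because compound 1 with its methyl gives 20 nM and shows how far a small group can move the number.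

Compound 4 is therefore expected to give about 1200 nM, with a range from 150 nM to 6000 nM. The expected step is a 2.1-fold lower number from compound 3 to compound 4 (0.33 log units; beyond the scatter).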

Compound 4, half-maximal inhibitory concentration: 2360 nM
The estimate for compound 4 lay 2.0-fold (0.29 log units) below the measured number, within the range that was stated.
By their numbers in this assay, from the lowest: compound 1; then compounds 2, 4 and 3 (each within the scatter of the next).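

In this assay, replacing one halogen with another on this aromatic carbon, para to a large group, gives a step within the scatter (a 1.1-fold lower number from compound 3 to compound 4 (0.03 log units; within the scatter)). Fluoro also lies within the scatter of methoxy (a 1.4-fold higher number from compound 2 to compound 4 (0.14 log units; within the scatter)), so fluoro, bromo and methoxy now form a single cluster of numbers, and methyl alone stands apart from them by a large step (a 120-fold higher number from compound 1 to compound 4 (2.07 log units; beyond the scatter)). Among these four groups, the position therefore separates methyl from the other three and does not separate the two halogens from each other, and no measurement here explains why methyl behaves differently.

The compounds shown leave open whether the low number belongs to methyl alone or would also appear with ethyl, a longer chain or another carbon-only group such as cyclopropyl. They also leave open what an amine or a carboxylic acid would do at this position, and whether methyl would stand apart in the same way if another part of the shared core were changed.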